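The source may report more compounds than this note shows. Statements on the series, on what has been measured and on what is new or still open speak of the compounds shown alone.

Measured so far:
compound 1, `CCCCCCCC/C=C/CCCCCCCC(=O)Nc1ccccc1CC`, 1200 nM
compound 2, `CCCCCCCC/C=C/CCCCCCCC(=O)Nc1ccc(OC)cc1OC`, 3000 nM

Both numbers come from an assay on microsomes from intestine for inhibition of acyl-CoA:cholesterol acyltransferase (Oryctolagus cuniculus); a higher number here means a weaker inhibitor, a lower number a stronger inhibitor. Compound 2 has the higher of the two numbers in this assay; the nearest is compound 1, and the step of a 2.5-fold higher number from compound 1 to compound 2 (0.40 log units; beyond the scatter) lies beyond the scatter, so compound 2 is the weaker inhibitor of the two. Compound 3, `CCCCCCCC/C=C/CCCCCCCC(=O)Nc1cccc(C)c1[N+](=O)[O-]`, differs from compound 2 in one place: 3-methyl-2-nitrophenyl in place of 2,4-dimethoxyphenyl on an amide-type nitrogen. For the measured compounds named here, the only measured step that bears on this change is the earlier swap of one aryl group for another on the same amide nitrogen, a 2.5-fold higher number from compound 1 to compound 2 (0.40 log units; beyond the scatter), which was modest in size. Nothing measured involves a nitro or a methyl on that aryl, so the direction of the new step cannot be read from the data; a modest step in either direction is the most that can be expected. The expected step is a 1.2-fold lower number from compound 2 to compound 3 (0.08 log units; within the scatter). Compound 3 is therefore estimated at about 2500 nM, with a range from 800 nM to 8000 nM.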

Compound 3, half-maximal inhibitory concentration: 12000 nM
Compound 3: the middle estimate sits 4.8-fold (0.68 log units) below what was measured, outside the stated range (above it).
By their numbers in this assay, from the lowest: compound 1; then compound 2; then compound 3.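

Replacing 2,4-dimethoxyphenyl with 3-methyl-2-nitrophenyl on the amide-type nitrogen gives a 4.0-fold higher number from compound 2 to compound 3 (0.60 log units; beyond the scatter) in this assay, so two groups with matching counts of heavy atoms and hydrogen-bond acceptors are far from interchangeable at this position. Against 2-ethylphenyl, the same group gives a 10-fold higher number from compound 1 to compound 3 (1.00 log units; beyond the scatter), the widest gap among these three compounds, which shows that changing the aryl group alone, with the long unsaturated chain held fixed, can move the number considerably. Nothing measured here explains why this aryl group gives the highest number. The compounds shown do not separate the contribution of the nitro from that of the methyl on this ring. From the compounds shown here alone, whether an amine or a carboxylic acid in place of the nitro would give a lower number also remains open.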